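The source may hold more compounds than are shown below. What is called first, only, known or untested is meant among the compounds shown, and "the series" means these compounds.

Measured so far:
- compound 1 `Cc1ccsc1-c1cc(-c2ccco2)cc(-c2cccs2)n1`: > 100000 nM
- compound 2 `Cc1ccsc1-c1cc(-c2ccco2)cc(-c2ccsc2)n1`: > 100000 nM

In a functional assay on DU-145 cells (Homo sapiens) for cytotoxicity, with a stated time of 3 days (on this read-out higher numbers stand for weaker inhibition and lower numbers for stronger inhibition), compound 1 gives > 100000 nM, which is a limit and not a number. Compound 2 gives > 100000 nM, also a limit. Compound 2 therefore stands at the limit of > 100000 nM in this assay, at which 2 of the 2 values shown sit.

Compound 3 `Cc1ccsc1-c1cc(-c2ccco2)cc(-c2sccc2C)n1` carries 3-methylthiophen-2-yl in place of thiophen-3-yl on an aromatic carbon, next to the ring nitrogen: 3-methylthiophen-2-yl in place of thiophen-3-yl on an aromatic carbon.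

Going by the values given here, the one measured step exchanges a group at this same place: a step that the two limits leave unreadable from compound 1 to compound 2. It offers no size to carry over, so no step beyond the scatter is expected in this assay. This expectation rests on the limit of compound 2, > 100000 nM. The expected step is a number no higher from compound 2 to compound 3 (the limit leaves the size open). Compound 3 is estimated at 100000 nM, with an expected range of 40000 nM to 200000 nM.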

Compound 3, half-maximal inhibitory concentration: 98200 nM
The estimate for compound 3 lay 1.0-fold (0.01 log units) above the measured number, and the stated range covers the measured number.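

Going by these compounds alone, at the place next to the ring nitrogen, 3-methylthiophen-2-yl in place of thiophen-3-yl gives the first step with a readable floor in this assay: an at least 1.0-fold lower number from compound 2 to compound 3 (0.00 log units; that floor lies within the scatter). Methyl in place of hydrogen on an aromatic carbon gives the same kind of result, an at least 1.0-fold lower number from compound 1 to compound 3 (0.00 log units; that floor lies within the scatter). Neither floor separates compound 3 from the two other compounds, and the values at this place still sit mostly at a limit: the limit of > 100000 nM in this assay, at which 2 of the 3 values shown sit.

Going by these compounds, the full size of both steps stays open, as compound 1 and compound 2 carry limits and not numbers. Also open, on these data alone, is whether an amine or a carboxylic acid at this place, or a longer chain in place of the methyl, would shift the number beyond the scatter in this assay.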